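Swapping a hydroxy for a methyl on a shared core

The source may hold more compounds than are shown below. What is called first, only, known or untested is meant among the compounds shown, and "the series" means these compounds.

Of the compounds shown here, three that share one core have been tested in an assay on isolated protein for inhibition of alpha-galactosidase (Coffea arabica), tested at 1000 uM; on this read-out lower numbers stand for less inhibition and higher numbers for more inhibition at the one concentration tested (going by the name of the read-out). Compound 1 `OC[C@]1(c2ccc(F)cc2)NC[C@H](O)[C@H]1O` gives 0%, compound 2 `Cc1ccc([C@]2(CO)NC[C@@H](O)[C@@H]2O)cc1` gives 1.6%, and compound 3 `OC[C@]1(c2ccc(O)cc2)NC[C@H](O)[C@H]1O` gives 3.6%. Compound 3 has the highest of the three numbers, but the gap to compound 2 and the gap to compound 1 both lie within the scatter, so no order among them can be claimed. Within the data shown here, the one measured step, hydroxy in place of fluoro on an aromatic carbon, is a number 3.6 percentage points higher from compound 1 to compound 3 (within the scatter), also within the scatter.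

Compound 4 `Cc1ccc([C@@]2(CO)NC[C@H](O)[C@H]2O)cc1` is the next compound. The change from compound 3 to compound 4 is methyl in place of hydroxy on an aromatic carbon. Among the measured compounds shown here, no measured step bears directly on a methyl entering at this position; compound 2 carries the same methyl and gives a low number, as do all three measured compounds. The expected step in this assay is therefore a number 1.6 percentage points lower from compound 3 to compound 4 (within the scatter), none beyond the scatter. Compound 4 is estimated to give 2%, with a range from -5% to 10%.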

Compound 4, a percentage reported as inhibition, at one concentration (the size of the read-out at that concentration, not a potency): 0%
Compound 4: middle estimate off by 2 percentage points, on the high side; the measured number falls inside the stated range.
By their numbers in this assay, from the lowest: compounds 1, 4, 2 and 3 (each within the scatter of the next).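

In this assay, putting methyl in place of hydroxy on this aromatic carbon gives a number 3.6 percentage points lower from compound 3 to compound 4 (within the scatter), and methyl in place of fluoro gives no change at the digits printed from compound 1 to compound 4 (within the scatter), so hydroxy, fluoro and methyl cannot be told apart at this position. Compound 4 also adds a comparison of a new kind, a mirror-image pair, with a number 1.6 percentage points lower from compound 2 to compound 4 (within the scatter), so inverting all the stereocentres brings no readable difference here either. This step tests configuration alone, with no change of group mixed in: the fact that compounds 2 and 4 differ only in the configuration as drawn

Still open, going by these compounds, is whether an amine or a carboxylic acid on this aromatic carbon, or a longer chain there, would move the number beyond the scatter. On these data alone, it is also open whether the mirror-image forms would differ on another enzyme.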